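This account rests on a few compounds, and the source may have more. Where it says the series, first, only, none or still open, it means among the compounds named here.

Working notes on the series. Within the data shown here, the core is shared; compound 1 `Oc1ccc(/C=N/NC(=S)Nc2ccccc2)cc1` gives 242000 nM in an assay for inhibition of ribonucleoside-diphosphate reductase RR1 (Homo sapiens), with a stated time of 30 min (on this read-out lower numbers stand for stronger inhibition and higher numbers for weaker inhibition), and stands lowest of the two numbers so far, its nearest neighbour being compound 2 `Oc1ccc(/C=N/NC(=S)Nc2ccc(Cl)cc2)cc1`, which gives 287000 nM in this assay. Among the measured compounds shown here, the one step known on this aromatic ring, chloro in place of hydrogen on an aromatic carbon, gave a 1.2-fold higher number from compound 1 to compound 2 (0.07 log units; within the scatter). Compound 3 `Cc1cccc(NC(=S)N/N=C/c2ccc(O)cc2)c1` differs from compound 1 by methyl in place of hydrogen on an aromatic carbon, meta to a large group. Given that the chloro step fell within the scatter, no step beyond the scatter is expected for compound 3 in this assay, which is estimated at 250000 nM (range 120000 nM to 520000 nM), an expected step of a 1.0-fold higher number from compound 1 to compound 3 (0.01 log units; within the scatter).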

Compound 3, half-maximal inhibitory concentration: 30400 nM
The estimate for compound 3 lay 8.2-fold (0.92 log units) above the measured number, outside the stated range (below it).
By their numbers in this assay, from the lowest: compound 3; then compounds 1 and 2 (each within the scatter of the next).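

In this assay, methyl in place of hydrogen on an aromatic carbon, meta to a large group, gave an 8.0-fold lower number from compound 1 to compound 3 (0.90 log units; beyond the scatter) and so moved the number beyond the scatter, which the chloro step had not done. This aromatic ring therefore tolerates a change that lowers the number, and one added carbon is enough to do so. Nothing at hand bears on the reason for this step. From the compounds shown here alone, whether ethyl, methoxy or an amine at this place would also lower the number remains open. So does whether chloro placed meta to the large group would behave as methyl does.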